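The source may report more compounds than this note shows. Statements on the series, on what has been measured and on what is new or still open speak of the compounds shown alone.

Measured so far in an ADME assay on MDCK cells (Canis lupus familiaris) for cytotoxicity, read by microscopy, with a stated time of 48 h; on this read-out lower numbers stand for higher toxicity in this test and higher numbers for lower toxicity in this test:
- compound 1 `C[C@H]1[C@H](NCc2cc(C3CC3)cs2)C[C@H]2C[C@@H]1C2(C)C`: 25000 nM
- compound 2 `Cc1ccc(CN[C@@H]2C[C@H]3C[C@@H]([C@H]2C)C3(C)C)s1`: 780 nM
- compound 3 `C[C@H]1[C@H](NCc2sccc2C2CCCCC2)C[C@H]2C[C@@H]1C2(C)C`: 1560 nM

Compound 1 stands at the highest of the three numbers in this assay, that is, the least toxic in this test. Its nearest neighbour is compound 3, whose number is lower by more than the usual scatter; compound 2 sits lower still, again well beyond the scatter. Going by the values given here, both companions carry a different group on the ring than compound 1, and no single-point step between any two of the measured compounds is available, so the spread among them is noted only as it stands.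

The unmeasured compound 4 `C=C(C)c1csc(CN[C@@H]2C[C@H]3C[C@@H]([C@H]2C)C3(C)C)c1` keeps the core and the ring of compound 1 and rearranges the same atoms of the substituent: 1-methylethenyl in place of cyclopropyl on an aromatic carbon. Among the compounds with values here, nothing among the measured pairs isolates a change of this kind. Given that compound 1 gives 25000 nM and that the new group is the same size and same atom count, no step beyond the scatter is expected for a 1.7-fold lower number from compound 1 to compound 4 (0.22 log units; within the scatter), with a slight lean toward a lower number. Compound 4 is therefore estimated at 15000 nM, in the range 4000 nM to 50000 nM.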

Compound 4, minimum cytotoxic concentration: 25000 nM
Estimate against measurement, compound 4: 1.7-fold (0.22 log units) below; the range from low to high includes it.
By their numbers in this assay, from the lowest: compounds 2 and 3 (each within the scatter of the next); then compounds 1 and 4 (each within the scatter of the next).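

In this assay, going by these compounds alone, the swap of 1-methylethenyl in place of cyclopropyl on an aromatic carbon gives no change at the digits printed from compound 1 to compound 4 (within the scatter) and is the first step that differs in one place. On the core of compound 1, at this place two ring bonds from the ring sulfur, the three-membered ring of carbon can therefore be exchanged for an open group with one double bond outside aromatic rings without a step beyond the scatter. Nothing measured here accounts for the two groups reading alike.

Open, going by these compounds, is how this position responds to a group of another kind, such as an amine, a carboxylic acid or a longer chain. Also open, on these data alone, is whether the same swap reads alike on another aromatic carbon of the ring.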